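A few compounds are considered here, and "the series" means these few. Any claim that something is new, unique, unknown or untested is made for them only; others in the source may bear on it.

Measured compounds:
Compound 1 `O=C(C1CCC1)N1CC(c2nc(-c3cccc(Cl)c3)no2)C1`: in an assay on HEK293 cells for positive allosteric modulation of metabotropic glutamate receptor 5 (Homo sapiens), read by FLIPR (a lower number here means that less compound is needed, a higher number that more compound is needed for the effect), compound 1 gives > 10000 nM, a limit of the assay and not a number.
Compound 2 `O=C(N1CCCCCC1)N1CC(c2nc(-c3cccc(Cl)c3)no2)C1`: in this assay compound 2 gives 47 nM.
Compound 3 `O=C(c1ccccc1F)N1CC(c2nc(-c3cccc(Cl)c3)no2)C1`: in this assay compound 3 gives > 10000 nM, again a limit of the assay and not a number.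

Compound 3 therefore stands at the weak end of what is shown, at the limit of > 10000 nM in this assay, at which 2 of the 3 values shown sit. The step that the two limits leave unreadable from compound 1 to compound 3 cannot be sized. The readable steps are an at least 210-fold lower number from compound 1 to compound 2 (2.32 log units; beyond the scatter) and an at least 210-fold higher number from compound 2 to compound 3 (2.32 log units; beyond the scatter).

Compound 4 `O=C(C1CCC2(CCC2)CC1)N1CC(c2nc(-c3cccc(Cl)c3)no2)C1` is the next compound; it differs from compound 3 in one place: a group of 9 heavy atoms (9 carbon; one four-membered non-aromatic ring of carbon only, one six-membered non-aromatic ring of carbon only) in place of a group of 7 heavy atoms (6 carbon, 1 fluorine; one six-membered aromatic ring of carbon only), on a carbonyl carbon. Both readable steps bear on it, since each leads to or from the carbonyl substituent. For the measured compounds named here, compound 2, with azepan-1-yl there, is the only compound with a number, and the move to 2-fluorophenyl in compound 3 is large and upward. Compound 1, with the small non-aromatic cyclobutyl, sits at the limit; the group entering in compound 4 is non-aromatic as well but larger, closer in size to azepan-1-yl. A downward step beyond the scatter is expected, but with wide uncertainty, and compound 4 may still sit at the limit. The expected step is an at least 16-fold lower number from compound 3 to compound 4 (1.22 log units; beyond the scatter). For compound 4 the estimate in this assay is 600 nM, ranging from 60 nM to 10000 nM.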

Compound 4, half-maximal effective concentration: 1100 nM
Compound 4: the middle estimate sits 1.8-fold (0.26 log units) below what was measured, and the stated range covers the measured number.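

In this assay, for the compounds shown here, azepan-1-yl is no longer the only group on this carbonyl carbon that gives a number: the group with carbon only, holding a four-membered and a six-membered non-aromatic ring, gives an at least 9.0-fold lower number from compound 3 to compound 4 (0.95 log units; beyond the scatter) and an at least 9.0-fold lower number from compound 1 to compound 4 (0.95 log units; beyond the scatter). A nitrogen attached to the carbonyl carbon is therefore not required for a measurable number, although azepan-1-yl remains ahead, with a 23-fold higher number from compound 2 to compound 4 (1.37 log units; beyond the scatter). Both steps from the limit are bounded on one side only, as compound 1 and compound 3 carry a limit of the assay and not a number: the limit of > 10000 nM in this assay, at which 2 of the 4 values shown sit.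

The compounds shown leave open whether the gap between compound 2 and compound 4 follows the nitrogen in azepan-1-yl, its seven-membered ring or the shape of the group in compound 4; piperidin-1-yl and cycloheptyl on the same carbonyl carbon would begin to separate these. Also open, going by these compounds, is what the four-membered ring adds to the six-membered ring, a question that plain cyclohexyl at this place would address.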